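The source may report more compounds than this note shows. Statements on the series, on what has been measured and on what is new or still open speak of the compounds shown alone.

Compound 3 `O=S(=O)(NCCCNCc1ccc(-c2ccccc2)cc1)c1cc(C(F)(F)F)cc(C(F)(F)F)c1` gives 2800 nM in a toxicity assay on MCF-10A cells (Homo sapiens) for inhibition, read by MTT assay, with a stated time of 72 h (a lower number here means a stronger inhibitor of growth, a higher number a weaker inhibitor of growth), the lowest of the three numbers recorded there. Compound 2 `O=S(=O)(NCCCNCC1COc2ccccc2O1)c1cc(C(F)(F)F)cc(C(F)(F)F)c1` gives 3200 nM, which sits within the scatter of compound 3; compound 1 `O=S(=O)(NCCCNCc1cccc(Cl)c1)c1cc(C(F)(F)F)cc(C(F)(F)F)c1` gives 7000 nM, beyond the scatter of compound 3. Compound 4 `COc1ccc(CNCCCNS(=O)(=O)c2cc(C(F)(F)F)cc(C(F)(F)F)c2)cc1` has not yet been measured in this assay. It differs from compound 3 by methoxy in place of phenyl on an aromatic carbon.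

Among the compounds with values here, the one step recorded between measured compounds, a 2.2-fold lower number from compound 1 to compound 2 (0.34 log units; beyond the scatter), changes the whole ring system on the saturated chain carbon bound to the amine nitrogen and was modest in size. Within the data shown here, no recorded step exchanges a group on an aromatic carbon of the benzyl ring, so the change from compound 3 to compound 4 has no direct precedent. The two values of compound 1 and compound 3 show that a 3-chlorophenyl in place of the biphenyl ring gives a higher number, but these two compounds differ in more than one place. Given the modest size of every step seen so far, compound 4 is expected to show a small rise, a 1.6-fold higher number from compound 3 to compound 4 (0.21 log units; within the scatter), and its value in this assay is estimated at 4500 nM, with a range from 2000 nM to 10000 nM.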

Compound 4, concentration for 50% growth inhibition: 3100 nM
Compound 4: middle estimate off by 1.5-fold (0.16 log units), on the high side, within the range that was stated.
By their numbers in this assay, from the lowest: compounds 3, 4 and 2 (each within the scatter of the next); then compound 1.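

In this assay, the exchange on the aromatic carbon, para to a large group, gives a 1.1-fold higher number from compound 3 to compound 4 (0.04 log units; within the scatter), so here a phenyl of 6 heavy atoms and a methoxy of 2 heavy atoms, which brings 1 hydrogen-bond acceptor, cannot be told apart. Within the data shown here, the comparisons on the saturated chain carbon bound to an amine nitrogen divide in the same way: 4-methoxyphenyl in place of 2,3-dihydro-1,4-benzodioxin-2-yl gives a 1.0-fold lower number from compound 2 to compound 4 (0.01 log units; within the scatter), while 4-methoxyphenyl in place of 3-chlorophenyl gives a 2.3-fold lower number from compound 1 to compound 4 (0.35 log units; beyond the scatter), which leaves compound 1 as the one compound set apart from the other three by its number. No measurement shown here accounts for these steps.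

With only phenyl and methoxy shown on this aromatic carbon, it remains open whether a hydroxyl, a carboxylic acid or a dimethylamino group there would stay within the same narrow band of values. Also open, going by these compounds, is whether the flat response at this position would hold with a longer chain between the two nitrogens of the shared core.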